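The source may hold more compounds than are shown below. What is called first, only, known or untested is meant among the compounds shown, and "the series" means these compounds.

Compound 3 `N#CC1CN1C(N)=O` is the simplest member of this small set, a urea with a free amino group attached to the shared core. In a functional assay on WiDr cells (Homo sapiens) for inhibition (on this read-out higher numbers stand for weaker inhibition and lower numbers for stronger inhibition), compound 3 reaches only a limit of the assay, given as > 280000 nM. So where compound 3 stands is known only as that limit, as recorded in the limit of > 280000 nM in this assay, at which 1 of the 3 values shown sits. Two close relatives do give numbers. Compound 1 `CC(C)(C)NC(=O)N1CC1C#N` carries a tert-butyl on the same amide-type nitrogen, and in this assay compound 1 gives 180000 nM. Compound 2 `N#CC1CN1C(=O)Nc1ccc([N+](=O)[O-])cc1` carries a different substituent on that nitrogen, and in this assay compound 2 gives 4300 nM. Going from a tert-butyl to a bare hydrogen on that nitrogen gave an at least 1.5-fold higher number from compound 1 to compound 3 (0.19 log units; that floor lies within the scatter), a step that could not be sized precisely because one end is a limit.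

Compound 4 `CNC(=O)N1CC1C#N` has not yet been measured. It differs from compound 3 by methyl in place of hydrogen on an amide-type nitrogen. Going by the values given here, the one measured step that bears on it is the removal of tert-butyl, which shifted the number upward only at its floor; putting a methyl back is expected to move it, if at all, slightly the other way, by about an at least 1.1-fold lower number from compound 3 to compound 4 (0.04 log units; that floor lies within the scatter). The expected value for compound 4 is therefore 250000 nM, within a range from 100000 nM to 600000 nM.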

Compound 4, half-maximal inhibitory concentration: 21000 nM
Estimate against measurement, compound 4: 12-fold (1.08 log units) above; measured number below the stated range.
By their numbers in this assay, from the lowest: compound 2; then compound 4; then compound 1. At a limit, above all of these: compound 3.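

On this amide-type nitrogen, methyl in place of hydrogen gave an at least 13-fold lower number from compound 3 to compound 4 (1.12 log units; beyond the scatter) in this assay, so a single carbon here is enough to change the read-out, which the earlier step from tert-butyl to hydrogen did not show. Methyl in place of tert-butyl gave an 8.6-fold lower number from compound 1 to compound 4 (0.93 log units; beyond the scatter), so among compound 3, compound 4 and compound 1 the number does not move steadily in one direction as the group grows from hydrogen through methyl to tert-butyl, although compound 2, with its different substituent, gives a lower number still at 4300 nM. The step from hydrogen to methyl is only a floor, and its true size cannot be read: the limit of > 280000 nM in this assay, at which 1 of the 4 values shown sits.

On these data alone, whether ethyl, isopropyl or a longer chain on this nitrogen would give a number nearer to that of the methyl or of the tert-butyl compound remains open. As far as these compounds go, it is also open how much of the value of compound 2 goes with its nitro group, a question that a plain phenyl group on the same nitrogen could help to settle.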